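A Pyridine Ring in Place of a Methoxyphenyl Arm

A few compounds are considered here, and "the series" means these few. Any claim that something is new, unique, unknown or untested is made for them only; others in the source may bear on it.

Compound 1 `COc1cccc(/C=C/C(=O)c2ccc(OC)c3c2OC(C)(C)C=C3)c1` was tested in a functional assay on HCT-116 cells (Homo sapiens) for antiproliferative activity, read by MTT assay, with a stated time of 24 h; a higher number here means a weaker inhibitor, a lower number a stronger inhibitor. In this assay compound 1 gives only a limit, > 10000 nM. Compound 2 `COc1ccc(C(=O)/C=C/c2ccc(N(c3ccccc3)c3ccccc3)cc2)c2c1C=CC(C)(C)O2` also gives only a limit in this assay, > 10000 nM. Compound 3 `COc1ccc(C(=O)/C=C/c2cccc3ccccc23)c2c1C=CC(C)(C)O2` likewise gives only a limit in this assay, > 10000 nM. Compound 1 thus stands at the same point as every other measured compound, because of the limit of > 10000 nM in this assay, at which 3 of the 3 values shown sit. Compound 4 `COc1ccc(C(=O)/C=C/c2ccccn2)c2c1C=CC(C)(C)O2` differs from compound 1 in one place: pyridin-2-yl in place of 3-methoxyphenyl on a double-bonded chain carbon bound to a double-bonded chain carbon. Among the measured compounds shown here, no measured pair shows what such a change does, and nothing among the measured compounds points to the pyridin-2-yl group changing the outcome. Compound 4 is therefore expected to remain at the limit, with a step that the limit leaves unreadable from compound 1 to compound 4 expected to be no step beyond the scatter. The estimate for compound 4 in this assay is 15000 nM, between 5000 nM and 50000 nM.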

Compound 4, half-maximal inhibitory concentration: 6630 nM
Compound 4: the middle estimate sits 2.3-fold (0.35 log units) above what was measured; measured number inside the range.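

Compound 4 alone among the compounds shown gives a number rather than a limit in this assay and so shows that a change at this place can bring the reading inside the range of the assay. Pyridin-2-yl in place of 3-methoxyphenyl gives an at least 1.5-fold lower number from compound 1 to compound 4 (0.17 log units; that floor lies within the scatter) on this chain. The full size of that step cannot be read, and so it cannot be told apart from scatter: the limit of > 10000 nM in this assay, at which 3 of the 4 values shown sit.

As far as these compounds go, whether pyridin-3-yl or pyridin-4-yl would give a similar number remains open. So does the outcome with an amine or a carboxylic acid on the ring at this place.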